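The compounds below may be only part of what the source reports. "The series", "measured", "known", "first", "only" and "open" are said of these compounds alone.

Series with a shared core carrying a styryl sulfone arm. Among the compounds with values here, compound 1, `O=S(=O)(/C=C/c1ccc(Br)cc1)Cc1ccc(Nc2ncnc3ccccc23)cc1`, is the weaker of the two measured members: in a functional assay on OVCAR-8 cells (Homo sapiens) (on this read-out higher numbers stand for weaker inhibition of growth and lower numbers for stronger inhibition of growth), compound 1 gives 38000 nM, the highest of the two numbers. Within the data shown here, compound 2, `CC(C)(C)c1cc(/C=C/S(=O)(=O)Cc2ccc(Nc3ncnc4ccccc34)cc2)cc(C(C)(C)C)c1O`, gives in this assay a value of 5000 nM, a lower number than compound 1 by a margin beyond the scatter; no single-point step links these two, so their values are simply set side by side. Compound 3, `O=S(=O)(/C=C/c1ccc(C(F)(F)F)cc1F)Cc1ccc(Nc2ncnc3ccccc23)cc1`, is not yet measured. Relative to compound 1 it carries 2-fluoro-4-(trifluoromethyl)phenyl in place of 4-bromophenyl on a double-bonded chain carbon bound to a double-bonded chain carbon. Among the measured compounds shown here, no measured pair isolates this kind of change, so no step size can be read from the data, and only the two measured values give a frame. The expectation for compound 3 in this assay is a step from compound 1 that is small, most likely not beyond the scatter, with an estimated step of a 1.5-fold lower number from compound 1 to compound 3 (0.18 log units; within the scatter). The estimate for compound 3 in this assay is 25000 nM, with a range from 8000 nM to 80000 nM.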

Compound 3, concentration for 50% growth inhibition: 100000 nM
Compound 3: middle estimate off by 4.0-fold (0.60 log units), on the low side; the measured number lies above the stated range.
By their numbers in this assay, from the lowest: compound 2; then compound 1; then compound 3.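

This place, on a double-bonded chain carbon bound to a double-bonded chain carbon, now gives the series its first readable step: in this assay, 2-fluoro-4-(trifluoromethyl)phenyl in place of 4-bromophenyl gives a 2.6-fold higher number from compound 1 to compound 3 (0.42 log units; beyond the scatter) and so moves toward weaker inhibition of growth. The aryl group at this place is therefore not silent, even though both groups hold one six-membered aromatic ring of carbon only and 0 hydrogen-bond donors or acceptors, and the entering group holds more heavy atoms than the leaving group. No measurement bears on the origin of this shift, and the step stands as an observation only.

The change replaces the bromine with a trifluoromethyl group and adds a fluorine in the same swap, so the compounds shown cannot assign the step to either part. Also open, as far as these compounds go, is whether an amine or a carboxylic acid on the phenyl ring at this place would move the number in the opposite direction, or whether a methoxy group would leave it within the scatter of compound 1.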